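A few compounds are considered here, and "the series" means these few. Any claim that something is new, unique, unknown or untested is made for them only; others in the source may bear on it.

Working notes on the series in a toxicity assay on L02 cells (Homo sapiens) for cytotoxicity, read by MTT assay, with a stated time of 72 h; a lower number here means a stronger inhibitor, a higher number a weaker inhibitor.

Compound 1 `O=C1c2c[n+]([O-])c3ccccc3c2C(=O)c2c1c1ccccc1n2CCCCn1ccnc1` gives 150 nM; among the three measured compounds this is the lowest number, and both other compounds lie beyond the scatter from it. Compound 2 `O=C1c2c[n+]([O-])c3ccccc3c2C(=O)c2c1c1ccccc1n2CCN1CCCCC1` gives 1050 nM, a change of a 7.0-fold higher number from compound 1 to compound 2 (0.85 log units; beyond the scatter). Compound 3 `CN1CCN(CCCCCCn2c3c(c4ccccc42)C(=O)c2c[n+]([O-])c4ccccc4c2C3=O)CC1` gives 3800 nM, a change of a 25-fold higher number from compound 1 to compound 3 (1.40 log units; beyond the scatter); the step of a 3.6-fold higher number from compound 2 to compound 3 (0.56 log units; beyond the scatter) lies in the same direction.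

The next compound, compound 4 `CN1CCN(CCCCCn2c3c(c4ccccc42)C(=O)c2c[n+]([O-])c4ccccc4c2C3=O)CC1`, differs from compound 1 as follows: (4-methylpiperazin-1-yl)methyl in place of 1H-imidazol-1-yl on a saturated chain carbon, four bonds along the chain from an aromatic nitrogen

Among the compounds with values here, the step that bears most directly on this is the one from compound 1 to compound 3, where the same exchange, cut one bond further out, gave a large rise in the number. The step from compound 1 to compound 2 also rose, though by less. Both replacements of the imidazolyl group by a saturated amine ring raised the number, so a rise beyond the scatter is expected here too, most likely close in size to the step to compound 3, with some allowance for the shorter chain in compound 4. Compound 4 is therefore expected to give 2500 nM, in the range 800 nM to 8000 nM, an expected step of a 17-fold higher number from compound 1 to compound 4 (1.22 log units; beyond the scatter).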

Compound 4, half-maximal inhibitory concentration: 1640 nM
Compound 4: middle estimate off by 1.5-fold (0.18 log units), on the high side, within the range that was stated.
By their numbers in this assay, from the lowest: compound 1; then compounds 2 and 4 (each within the scatter of the next); then compound 3.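

In this assay, (4-methylpiperazin-1-yl)methyl in place of 1H-imidazol-1-yl, on a saturated chain carbon four bonds along the chain from an aromatic nitrogen, gives an 11-fold higher number from compound 1 to compound 4 (1.04 log units; beyond the scatter), so the large rise seen with the longer 2-(4-methylpiperazin-1-yl)ethyl group also appears with this shorter one. With the 4-methylpiperazin-1-yl ring held fixed, the chain itself now has a readable effect: the shorter chain gives a 2.3-fold lower number from compound 3 to compound 4 (0.36 log units; beyond the scatter), yet this recovers only part of the rise and compound 1 stays apart from all three amine compounds, while a 1.6-fold higher number from compound 2 to compound 4 (0.19 log units; within the scatter) leaves the piperidin-1-yl and 3-(4-methylpiperazin-1-yl)propyl groups unseparated. No supporting data are available to explain these differences.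

Still open, from the compounds shown here alone, is whether a 4-methylpiperazin-1-yl ring on a chain shorter than that of compound 4 would continue the fall in the number seen from compound 3 to compound 4. Also open, going by these compounds, is whether another aromatic ring, such as 1H-pyrazol-1-yl, on the chain of compound 1 would stay near the number of compound 1, 150 nM, or whether a morpholine ring would behave like the saturated amine rings.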